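The compounds below may be only part of what the source reports. "The series", "measured", "known", "first", "only" and "open" are said of these compounds alone.

Measured so far in an ADME assay on HEK293 cells (Homo sapiens) for cytotoxicity, read by reporter gene assay and resazurin assay, with a stated time of 48 h; a lower number here means that less compound is tolerated, a higher number that more compound is tolerated:
- Compound 1 `O=C(Nc1ccccc1)c1cccc(Br)c1`: > 100000 nM, a limit.
- Compound 2 `O=C(Nc1ccc(Sc2nc3ccccc3s2)c(Cl)c1)c1cc(Br)cc(Br)c1`: > 100000 nM, a limit.
- Compound 3 `O=C(Nc1ccc(Sc2nc3ccccc3s2)cc1)c1cc(Br)cc(Br)c1`: > 100000 nM, a limit.

Compound 2 therefore stands at a limit and not at a number, and it has no measured neighbour with a number: the limit of > 100000 nM in this assay, at which 3 of the 3 values shown sit.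

Compound 4 `O=C(Nc1ccc(Sc2nc3ccccc3s2)c(Cl)c1)c1cccc(Br)c1O` differs from it by 3-bromo-2-hydroxyphenyl in place of 3,5-dibromophenyl on a carbonyl carbon.

Among the compounds with values here, the only measured step, a step that the two limits leave unreadable from compound 2 to compound 3, is a swap of chloro for hydrogen elsewhere in the molecule, so it sets no size for this change. Within the data shown here, no measured step involves this replacement. In this assay, any readable value is expected on the side where less compound is tolerated, with no firm size. The expected step is an at least 1.6-fold lower number from compound 2 to compound 4 (0.22 log units; that floor lies within the scatter).

For compound 4 the estimate is 60000 nM, with an expected range of 15000 nM to 100000 nM.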

Compound 4, half-maximal cytotoxic concentration: 64000 nM
For compound 4 the middle estimate is 1.1-fold (0.03 log units) below the measured one; measured number inside the range.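

In this assay, within the data shown here, compound 4 is the first compound to give a number rather than a limit, 64000 nM. Placing 3-bromo-2-hydroxyphenyl in place of 3,5-dibromophenyl on the carbonyl carbon gives an at least 1.5-fold lower number from compound 2 to compound 4 (0.19 log units; that floor lies within the scatter). That step is readable only as a floor, set by a limit: the limit of > 100000 nM in this assay, at which 3 of the 4 values shown sit.

The step between the two limits cannot be read, and the gain of the hydroxy group is not separated from the loss of one bromine. Going by these compounds, how an amine or a carboxylic acid in place of that hydroxy group would read in this assay remains open.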